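The source may hold more compounds than are shown below. What is called first, only, known or untested is meant among the compounds shown, and "the series" means these compounds.

Measured so far:
Compound 1 `CCOC(=O)N1CCN(Cc2c(O)c([C@H]3CCN(C)C[C@H]3O)c3oc(C)cc(=O)c3c2O)CC1`: 16%
Compound 2 `Cc1oc2c([C@H]3CCN(C)C[C@H]3O)c(O)cc(O)c2c(=O)c1C(O)c1ccc([N+](=O)[O-])cc1`: 0%

In a functional assay on HL-60 cells (Homo sapiens) for inhibition, read by MTT assay, with a stated time of 48 h, tested at 10 uM (a lower number here means less inhibition of growth, a higher number more inhibition of growth at the concentration tested), compound 2 gives 0%, the lower of the two numbers, and compound 1 gives 16%. The gap between these two compounds lies beyond the scatter. Compound 3 `Cc1oc2c([C@H]3CCN(C)C[C@H]3O)c(O)cc(O)c2c(=O)c1C(O)c1cccc(Cl)c1` has 3-chlorophenyl in place of 4-nitrophenyl on a saturated chain carbon bound to an aromatic carbon and an oxygen on a saturated carbon. For the measured compounds named here, no measured pair shows this change, so in this assay no step beyond the scatter is expected. The expected step is a number 6 percentage points higher from compound 2 to compound 3 (within the scatter). The estimate for compound 3 is 6%, with an expected range of 0% to 20%.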

Compound 3, percent growth inhibition at one concentration: 22%
For compound 3 the middle estimate is 16 percentage points below the measured one; the whole stated range lies below it.
By their numbers in this assay, from the lowest: compound 2; then compounds 1 and 3 (each within the scatter of the next).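

Where the saturated chain carbon bound to an aromatic carbon and an oxygen carries 3-chlorophenyl in place of 4-nitrophenyl, this assay shows a number 22 percentage points higher from compound 2 to compound 3 (beyond the scatter). This position therefore responds to the aryl group it carries, something compounds 1 and 2 could not show, as they differ in more than one place. Nothing measured here gives a reason for the step. From the compounds shown here alone, it remains open whether the chlorine's arrival or the nitro group's departure matters more; plain phenyl or 4-chlorophenyl at this carbon would separate the two.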